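Trimethoxyphenyl series: aryl swap on the saturated ring carbon

The source may report more compounds than this note shows. Statements on the series, on what has been measured and on what is new or still open speak of the compounds shown alone.

Measured so far:
compound 1 `COc1cc(C(=O)N/N=C/c2ccccc2C(F)(F)F)cc(OC)c1OC`: 45%
compound 2 `COc1cc(C2=NN(C(C)=O)C(c3ccccc3C(F)(F)F)O2)cc(OC)c1OC`: -11%

In a functional assay on PC-3 cells (Homo sapiens) for antiproliferative activity, read by MTT assay, tested at 1 uM (on this read-out higher numbers stand for a stronger effect at the one concentration tested and lower numbers for a weaker effect), compound 1 gives 45%. Compound 2, the cyclised acetyl-bearing analogue, gives -11% in this assay, a read-out at or below zero. Going by the values given here, compound 2 therefore stands lowest of the two numbers; its only neighbour, compound 1, lies higher by a gap beyond the usual scatter. Among the compounds with values here, no pair of measured compounds differs in a single place, so no measured step is available to rest a prediction on.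

Compound 3 `COc1cc(C2=NN(C(C)=O)C(c3ccc(Cl)c([N+](=O)[O-])c3)O2)cc(OC)c1OC` keeps the core of compound 2 and differs from it by 4-chloro-3-nitrophenyl in place of 2-(trifluoromethyl)phenyl on a saturated ring carbon. Nothing among the two measured compounds tells how this exchange on the saturated ring carbon plays out in this assay. With compound 2 at -11%, a modest upward step is expected, most likely within the scatter or little beyond it. The expected step from compound 2 to compound 3 is a number 16 percentage points higher from compound 2 to compound 3 (beyond the scatter), and compound 3 is estimated at 5% in this assay, between -20% and 35%.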

Compound 3, a percentage reported as inhibition, at one concentration (the size of the read-out at that concentration, not a potency): 43.3%
Estimate against measurement, compound 3: 38.3 percentage points below, and the stated range ends below it.
By their numbers in this assay, from the lowest: compound 2; then compounds 3 and 1 (each within the scatter of the next).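

In this assay, 4-chloro-3-nitrophenyl in place of 2-(trifluoromethyl)phenyl on the saturated ring carbon gives a number 54.3 percentage points higher from compound 2 to compound 3 (beyond the scatter), so the read-out of this acetyl-bearing core is strongly tied to the aryl group at this one position. The read-out at or below zero seen for compound 2 therefore does not hold for the core as a whole: with the core unchanged, compound 3 gives 43.3% in this series. The two aryl groups match in heavy-atom count and each holds one six-membered aromatic ring, yet the entering group carries hydrogen-bond acceptors and the leaving group none, and no measurement shown links any such difference to the step.

The exchange alters the whole substitution of the aryl ring in one move, so the shares of the chloro group, the nitro group, the loss of trifluoromethyl and the shift in substitution pattern remain unseparated. Also open, as far as these compounds go, are how an amine or a carboxylic acid in place of the nitro group would read out, and whether the same aryl exchange on the open-chain core of compound 1 would give a step of similar size.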